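Working notes: replacing 4-fluorophenyl with pyridin-2-yl in the series

The compounds below may be only part of what the source reports. "The series", "measured", "known", "first", "only" and "open" are said of these compounds alone.

Measured so far in a toxicity assay on cells (Macrophage, Mus musculus, strain BALB/c) for cytotoxicity, read by MTT assay; a lower number here means a stronger inhibitor, a higher number a weaker inhibitor:
- compound 1 `C=CCOc1cc(/C=C/C(=O)c2c(O)cc(O)cc2OC)cc(OCC=C)c1Br` gives 11500 nM
- compound 2 `C=CCOc1cc(OC)c(C(=O)/C=C/c2ccc(F)cc2)c(OCC=C)c1` gives 13800 nM
- compound 3 `COCc1cc(O)c(C(=O)/C=C/c2cc(OC)c(OC)c(OC)c2)c(OC)c1` gives 133000 nM

Compound 2 at 13800 nM lies within the scatter of compound 1 at 11500 nM. Compound 3 at 133000 nM stands apart from compound 2 on the side of the higher number, and this gap lies beyond the scatter.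

Compound 4 `C=CCOc1cc(OC)c(C(=O)/C=C/c2ccccn2)c(OCC=C)c1` differs from compound 2 in one place (pyridin-2-yl in place of 4-fluorophenyl on a double-bonded chain carbon bound to a double-bonded chain carbon) with pyridin-2-yl in place of 4-fluorophenyl on a double-bonded chain carbon bound to a double-bonded chain carbon.

Going by the values given here, no two measured compounds differ in one place only, so no measured step speaks directly to this change. Compound 1 at 11500 nM and compound 2 at 13800 nM differ in more than one place and still lie within the scatter of each other. The expectation in this assay is therefore for no step beyond the scatter, with a slightly higher number if there is any shift. Compound 3 at 133000 nM shows that the series can reach much higher numbers, which keeps the upper end of the expectation wide.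

The expected step of a 1.3-fold higher number from compound 2 to compound 4 (0.12 log units; within the scatter) stays within the scatter of repeated measurements. For compound 4 the estimated value is 18000 nM with an expected range from 7000 nM to 50000 nM for now.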

Compound 4, half-maximal inhibitory concentration: 12500 nM
Beside the measured number, compound 4's estimate is 1.4-fold (0.16 log units) above it, within the range that was stated.
By their numbers in this assay, from the lowest: compounds 1, 4 and 2 (each within the scatter of the next); then compound 3.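

Working notes, pyridin-2-yl at this place: in this assay the series now has its first comparison of compounds that differ in one place only, and it reads as a 1.1-fold lower number from compound 2 to compound 4 (0.04 log units; within the scatter) for pyridin-2-yl in place of 4-fluorophenyl on a double-bonded chain carbon bound to a double-bonded chain carbon. The earlier compounds shown here differ in more than one place and could not isolate this position; here, swapping a carbon-only aromatic ring carrying fluorine for a ring with one hetero atom and one hydrogen-bond acceptor produces no step beyond the scatter. Nothing in the available data offers an explanation for this result.

Open, going by these compounds, is whether a phenyl ring carrying a carboxylic acid or a dimethylamino group at this place would move the number in this assay beyond the scatter, and whether the same exchange would read alike on the core of compound 1 or the core of compound 3. Going by these compounds alone, no one-place step yet connects to compound 3 at 133000 nM so the structural feature tied to that value remains unassigned.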